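Hydrazone aryl variation on the naphthyl-tetrazole thioacetohydrazide series

The source may hold more compounds than are shown below. What is called first, only, known or untested is meant among the compounds shown, and "the series" means these compounds.

Measured so far in an ADME assay on MT4 cells (Homo sapiens) for cytotoxicity, read by MTT assay; a higher number here means that more compound is tolerated, a lower number that less compound is tolerated:
- compound 1, `O=C(CSc1nnnn1-c1cccc2ccccc12)N/N=C/c1cccs1`: > 316000 nM
- compound 2, `O=C(CSc1nnnn1-c1cccc2ccccc12)N/N=C/c1cccc(Cl)c1`: 240000 nM
- compound 3, `COc1ccc(/C=N/NC(=O)CSc2nnnn2-c2cccc3ccccc23)c(OC)c1`: 28300 nM

The value of compound 1 is a limit of this assay, not a number (the limit of > 316000 nM in this assay, at which 1 of the 3 values shown sits). Compound 3 stands lowest of the two numbers given; its nearest neighbour is compound 2, and the step of an 8.5-fold lower number from compound 2 to compound 3 (0.93 log units; beyond the scatter) lies beyond the scatter. The step of an at least 11-fold lower number from compound 1 to compound 3 (1.04 log units; beyond the scatter) points the same way, while an at least 1.3-fold lower number from compound 1 to compound 2 (0.11 log units; that floor lies within the scatter) is within the scatter.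

Compound 4, `O=C(CSc1nnnn1-c1cccc2ccccc12)N/N=C/c1ccc(O)cc1`, is not yet measured. It differs from compound 3 by 4-hydroxyphenyl in place of 2,4-dimethoxyphenyl on a carbon with a double bond to nitrogen. Both measured steps onto 2,4-dimethoxyphenyl lowered the number by a clear margin, so leaving that group for a different phenyl is expected to move the number back up. With 4-hydroxyphenyl carrying one hydrogen-bond donor instead of two methoxy acceptors, compound 4 is expected to return toward the region of compound 2 (240000 nM). The estimated step of a 5.3-fold higher number from compound 3 to compound 4 (0.72 log units; beyond the scatter) is expected to be well beyond the scatter. Compound 4 is estimated at 150000 nM, with a range from 40000 nM to 320000 nM.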

Compound 4, half-maximal cytotoxic concentration: > 309000 nM
Compound 4 ended at the assay's limit (the forecaster's own chance of this, stated with the estimate: 35%); at least 2.0-fold (0.31 log units) between middle value and limit.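

In this assay compound 4 gives a limit of the assay, not a number: the limit of > 309000 nM in this assay, at which 1 of the 4 values shown sits.

Leaving 2,4-dimethoxyphenyl for 4-hydroxyphenyl gives an at least 10-fold higher number from compound 3 to compound 4 (1.03 log units; beyond the scatter), which shows that the low number of compound 3 belongs to 2,4-dimethoxyphenyl and not to a phenyl ring on this carbon as such. Against 3-chlorophenyl the change gives an at least 1.2-fold higher number from compound 2 to compound 4 (0.10 log units; that floor lies within the scatter), so these two groups cannot be told apart here, and the step from compound 1 to compound 4 cannot be read.

The compounds shown leave open whether a single methoxy group on the phenyl is enough to bring the number down in this assay, or whether both are needed. From the compounds shown here alone, how a phenyl carrying a dimethylamino group or a carboxylic acid would stand also remains open.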